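Chloro for bromo: a small step repeated on a second core

The compounds below may be only part of what the source reports. "The series", "measured", "known", "first", "only" and "open" are said of these compounds alone.

Three compounds have been measured in a functional assay on MDA-MB-231 cells (Homo sapiens) for cytotoxicity, read by sulforhodamine B assay, with a stated time of 48 h; on this read-out higher numbers stand for weaker inhibition of growth and lower numbers for stronger inhibition of growth:
compound 1, `Cc1ccc2nc(/N=C3\C(=O)N(CN(c4ccccc4)c4ccccc4)c4cccc(Br)c43)sc2c1`, gives 75100 nM;
compound 2, `O=C1C(=O)N(CN2CCCCC2)c2cccc(Br)c21`, gives 30200 nM;
compound 3, `O=C1C(=O)N(CN2CCCCC2)c2cccc(Cl)c21`, gives 26500 nM.

Compound 1 gives the highest number of the three; compound 2 and compound 3 both lie below it by steps beyond the scatter. The difference between the core of compound 1 and the core of compound 2 is not broken down here. From compound 2 to compound 3 the change is chloro in place of bromo on an aromatic carbon, and it made a 1.1-fold lower number from compound 2 to compound 3 (0.06 log units; within the scatter). Compound 4, `Cc1ccc2nc(/N=C3\C(=O)N(CN(c4ccccc4)c4ccccc4)c4cccc(Cl)c43)sc2c1`, has not yet been measured in this assay; it arises from compound 1 by chloro in place of bromo on an aromatic carbon, the same change at the same place. Because the earlier step of a 1.1-fold lower number from compound 2 to compound 3 (0.06 log units; within the scatter) stayed within the scatter, compound 4 is expected to show only a 1.1-fold lower number from compound 1 to compound 4 (0.04 log units; within the scatter). Compound 4 is therefore estimated at 68000 nM, expected between 30000 nM and 150000 nM.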

Compound 4, concentration for 50% growth inhibition: 54000 nM
Estimate against measurement, compound 4: 1.3-fold (0.10 log units) above; measured number inside the range.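

In this assay chloro in place of bromo gave a 1.4-fold lower number from compound 1 to compound 4 (0.14 log units; within the scatter) and so left the number as unmoved as it had on the other core. This holds for two cores and one place on the ring only, and it does not show that the step would stay as small on any further core. Within that limit, the change carried over from one core to the other without a difference that can be told apart: the same change on two cores in this assay, a 1.1-fold lower number (0.06 log units; within the scatter) from compound 2 to compound 3 and a 1.4-fold lower number (0.14 log units; within the scatter) from compound 1 to compound 4, 1.2-fold (0.09 log units) apart, within the scatter of two such steps

On these data alone, what remains open is what a group other than these two halogens, such as fluoro, methoxy, a nitrile or an amine, would do on the same aromatic carbon. Equally open, as far as these compounds go, is whether such a group would give a larger step on one core than on the other.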